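Series notes: aryl swap on the triazole nitrogen

A few compounds are considered here, and "the series" means these few. Any claim that something is new, unique, unknown or untested is made for them only; others in the source may bear on it.

Compound 1 `CC(=O)Nc1ccc(-n2nncc2CN2C(=O)C3(C(C#N)=C(N)Oc4c(N)cc5nc6ccccc6nc5c43)c3ccccc32)cc1` carries a 4-acetamidophenyl group on the triazole nitrogen of the shared core. In a functional assay on HCT-116 cells (Homo sapiens) for antiproliferative activity, read by MTT assay, with a stated time of 48 h (on this read-out lower numbers stand for stronger inhibition and higher numbers for weaker inhibition), compound 1 gives only a limit of the assay, > 50000 nM. Compound 2 `COc1ccc(OC)c(-n2nncc2CN2C(=O)C3(C(C#N)=C(N)Oc4c(N)cc5nc6ccccc6nc5c43)c3ccccc32)c1` carries a 2,5-dimethoxyphenyl group at the same place. In this assay compound 2 gives again only a limit, > 50000 nM. Within the data shown here, the step that the two limits leave unreadable from compound 1 to compound 2 therefore cannot be read, and compound 2 stands nowhere on a number: it is known only as a limit, like compound 1, the sole other value shown.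

Compound 3 `N#CC1=C(N)Oc2c(N)cc3nc4ccccc4nc3c2C12C(=O)N(Cc1cnnn1-c1ccc(F)c(Cl)c1)c1ccccc12` differs from compound 2 in one place: 3-chloro-4-fluorophenyl in place of 2,5-dimethoxyphenyl on an aromatic nitrogen. Among the measured compounds shown here, the only measured step that touches this position is the one from compound 1 to compound 2, and its size is hidden by the two limits, which is the whole of the evidence, (the limit of > 50000 nM in this assay, at which 2 of the 2 values shown sit). For the measured compounds named here, no measured step gives a direction or a size for a change at this position. The expectation for compound 3 is that it also sits at the limit, with a step that the limit leaves unreadable from compound 2 to compound 3 that means no change beyond the scatter. The estimated value for compound 3 in this assay is 60000 nM, within a range from 15000 nM to 250000 nM.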

Compound 3, half-maximal inhibitory concentration: > 50000 nM
Compound 3: only a limit was reported; the forecaster's own chance of this, stated with the estimate: 80%; the middle value is on the limit's open side.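

In this assay compound 3 gives only a limit of the assay, > 50000 nM. No step among compound 1, compound 2 and compound 3 can be read: the limit of > 50000 nM in this assay, at which 3 of the 3 values shown sit.

The compounds shown leave open whether any aryl group at this triazole nitrogen gives a numerical value in this assay, and so the direction and size of a change at this position.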